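The source may report more compounds than this note shows. Statements on the series, on what has been measured and on what is new or still open speak of the compounds shown alone.

Compound 1 `CS(=O)(=O)c1ccc(Cc2nnc3n2N=C(c2ccc(Cl)cc2Cl)CS3)cc1` gives 24.2% in a functional assay on RAW264.7 cells (Mus musculus) for cytotoxicity, read by MTT assay, with a stated time of 48 h, tested at 25 uM; on this read-out lower numbers stand for a weaker effect and higher numbers for a stronger effect at the one concentration tested. Compound 2 `Cc1ccc(C2=Nn3c(Cc4ccc(S(C)(=O)=O)cc4)nnc3SC2)cc1` gives 1.26%.

Among the measured compounds shown here, on these two numbers compound 2 stands lowest, with compound 1 as its only neighbour. Compound 3 `CS(=O)(=O)c1ccc(Cc2nnc3n2N=C(c2ccc(O)c(C(N)=O)c2)CS3)cc1` differs from compound 2 by one change: 3-carbamoyl-4-hydroxyphenyl in place of 4-methylphenyl on a carbon with a double bond to nitrogen. For the measured compounds named here, the only measured step at this carbon is a number 22.9 percentage points lower from compound 1 to compound 2 (beyond the scatter), a swap of one aryl group for another at the same place. Going by the values given here, that step gives direction for how much this position can move the read-out, but no measured pair shows the entering group itself. A change of similar size, in either direction, is therefore possible. Compound 3 is estimated at 10%, in the range 0% to 30%, which means an expected step of a number 8.7 percentage points higher from compound 2 to compound 3 (within the scatter).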

Compound 3, a percentage reported as activity, at one concentration (the size of the read-out at that concentration, not a potency): 24.7%
Estimate against measurement, compound 3: 14.7 percentage points below; low and high end bracket the measured number.
By their numbers in this assay, from the lowest: compound 2; then compounds 1 and 3 (each within the scatter of the next).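

Placing 3-carbamoyl-4-hydroxyphenyl on the carbon with a double bond to nitrogen in place of 4-methylphenyl gives a number 23.4 percentage points higher from compound 2 to compound 3 (beyond the scatter) in this assay, so the read-out at this position can be restored by a group quite unlike 2,4-dichlorophenyl. Between those two groups the comparison shows a number 0.5 percentage points higher from compound 1 to compound 3 (within the scatter), and among these three compounds only the 4-methylphenyl compound stands apart. Nothing available explains these differences.

The compounds shown leave open whether the hydroxy group or the carbamoyl group carries the effect. Going by these compounds, an amine or a carboxylic acid on the same phenyl ring also remains untested here.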